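This account rests on a few compounds, and the source may have more. Where it says the series, first, only, none or still open, it means among the compounds named here.

In an ADME assay on MT4 cells (Homo sapiens) for cytotoxicity, read by MTT assay, with a stated time of 5 days (on this read-out lower numbers stand for higher toxicity in this test and higher numbers for lower toxicity in this test), three compounds that share one core and differ only in the ring amine on their side chain give closely similar numbers. Compound 1 (`COc1cc(Cc2cnc(/N=C3\C(=O)N(CN4CCCCC4C)c4ccc(Cl)cc43)nc2N)cc(OC)c1OC`) gives 97.3 ug/mL, compound 2 (`COc1cc(Cc2cnc(/N=C3\C(=O)N(CN4CCC(C)CC4)c4ccc(Cl)cc43)nc2N)cc(OC)c1OC`) gives 67.4 ug/mL and compound 3 (`COc1cc(Cc2cnc(/N=C3\C(=O)N(CN4CCN(C)CC4)c4ccc(Cl)cc43)nc2N)cc(OC)c1OC`) gives 80.7 ug/mL. Compound 3 therefore cannot be told apart from the other two.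

The next structure, compound 4 (`COc1cc(Cc2cnc(/N=C3\C(=O)N(CN4CCN(c5cccc(Cl)c5)CC4)c4ccc(Cl)cc43)nc2N)cc(OC)c1OC`), has 3-chlorophenyl in place of methyl on an amine nitrogen in a ring.

Going by the values given here, three measured steps bear on this, since each alters the same ring amine: a 1.4-fold lower number from compound 1 to compound 2 (0.16 log units; within the scatter), a 1.2-fold lower number from compound 1 to compound 3 (0.08 log units; within the scatter) and a 1.2-fold higher number from compound 2 to compound 3 (0.08 log units; within the scatter). All are small and within the scatter, yet none of them adds an aromatic ring, so they offer only a loose guide to a change of this size. A modest move towards higher toxicity is the cautious expectation, and it may not exceed the scatter. The estimate corresponds to an expected 1.5-fold lower number from compound 3 to compound 4 (0.17 log units; within the scatter). The expected value for compound 4 is 55 ug/mL, with an estimated range from 22 ug/mL to 120 ug/mL.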

Compound 4, half-maximal cytotoxic concentration: 39.2 ug/mL
Estimate against measurement, compound 4: 1.4-fold (0.15 log units) above; measured number inside the range.
By their numbers in this assay, from the lowest: compounds 4, 2, 3 and 1 (each within the scatter of the next, the first and the last beyond it).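

In this assay, putting 3-chlorophenyl in place of methyl on the amine nitrogen in the ring gives a 2.1-fold lower number from compound 3 to compound 4 (0.31 log units; beyond the scatter). Going by these compounds alone, this is the first step at the ring amine that lies beyond the scatter, although only modestly, and it goes towards higher toxicity in this test. The earlier swaps among the ring amines left the number within the scatter, so this position does respond to a change, at least to one that brings in a six-membered aromatic ring, yet nothing available here explains the shift.

On these data alone, it remains open whether the aromatic ring itself or its chlorine matters more, and a plain phenyl on the same nitrogen would separate the two. A benzyl group there would show whether the step persists when one carbon holds the ring away from that nitrogen.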